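The compounds below may be only part of what the source reports. "The series", "measured", "known", "first", "only" and "open" are said of these compounds alone.

Measured so far:
- compound 1 `COc1ccc(CN(C(=O)CCCCSc2nc3ccccc3o2)c2cc(OC)c(OC)c(OC)c2)cc1`: 45600 nM
- compound 2 `COc1ccc(CN(C(=O)CSc2ccccn2)c2cc(OC)c(OC)c(OC)c2)cc1`: 7510 nM

Both compounds share the same core and were run in a functional assay on PC-3 cells (Homo sapiens) for antiproliferative activity, read by MTT assay, with a stated time of 48 h; on this read-out higher numbers stand for weaker inhibition and lower numbers for stronger inhibition. Of the two numbers, compound 1 stands highest; the nearest is compound 2, whose value sits well beyond the usual scatter from that of compound 1. Within the data shown here, compound 2 differs from compound 1 in more than one place at once, so the two values show only that the pair spans a clear gap, and nothing can be traced to a single change.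

Compound 3 `COc1ccc(CN(C(=O)CCCSc2nc3ccccc3o2)c2cc(OC)c(OC)c(OC)c2)cc1` is not yet measured. It differs from compound 1 in one place: (1,3-benzoxazol-2-yl)sulfanyl in place of ((1,3-benzoxazol-2-yl)sulfanyl)methyl on a saturated chain carbon, three bonds along the chain from a carbonyl carbon. The chain between the carbonyl and the sulfur is thus one carbon shorter, with the benzoxazolyl sulfanyl end kept.

Among the measured compounds shown here, no measured step of the same kind exists here, so the direction of this change rests on nothing firm. A modest step toward a lower number is expected, a 1.5-fold lower number from compound 1 to compound 3 (0.18 log units; within the scatter), though a result within the scatter would not surprise. For compound 3 the expected value in this assay is 30000 nM, within the range 10000 nM to 90000 nM.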

Compound 3, half-maximal inhibitory concentration: 32700 nM
Compound 3: the middle estimate sits 1.1-fold (0.04 log units) below what was measured, within the range that was stated.
By their numbers in this assay, from the lowest: compound 2; then compounds 3 and 1 (each within the scatter of the next).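

In this assay, (1,3-benzoxazol-2-yl)sulfanyl in place of ((1,3-benzoxazol-2-yl)sulfanyl)methyl on a saturated chain carbon, three bonds along the chain from a carbonyl carbon, gives a 1.4-fold lower number from compound 1 to compound 3 (0.14 log units; within the scatter) and so this change at this position does not separate compound 3 from compound 1 on this read-out. The gap seen earlier can now be tied to one place: 2-((1,3-benzoxazol-2-yl)sulfanyl)ethyl in place of (pyridin-2-yl)sulfanyl on a saturated chain carbon bound to a carbonyl carbon gives a 4.4-fold higher number from compound 2 to compound 3 (0.64 log units; beyond the scatter) and that single replacement alters the chain and its ring-bearing end together. No measured evidence accounts for either step.

Still open, from the compounds shown here alone, is whether the gap follows the chain or the ring-bearing end, which a (pyridin-2-yl)sulfanyl group on a longer chain, set against the benzoxazolyl compounds, would help to settle. Also open, going by these compounds, is how an amine or a carboxylic acid at the end of the chain would read out in this assay on the shared core.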